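Swapping trifluoromethyl for chloro on a urea side chain

This account rests on a few compounds, and the source may have more. Where it says the series, first, only, none or still open, it means among the compounds named here.

Measured so far:
compound 1 `O=C(Nc1cccc(-n2cc(-c3ccncc3)c(-c3cc(O)cc(Cl)c3)n2)c1)Nc1ccc(Cl)c(Cl)c1` gives 88%
compound 2 `COc1cc(Cl)cc(-c2nn(-c3cccc(NC(=O)Nc4ccc(Cl)c(C(F)(F)F)c4)c3)cc2-c2ccncc2)c1` gives 103%

Both numbers come from a functional assay on T47D cells (Homo sapiens) for inhibition, read by sulforhodamine B assay, with a stated time of 48 h, tested at 0.1 uM; a lower number here means a stronger effect, a higher number a weaker effect of the compound at the concentration tested. Compound 2 stands highest of the two, and its nearest neighbour, compound 1, lies lower by a gap that is beyond the scatter. The two differ in more than one place, so no single change can be credited with that gap.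

Compound 3 `COc1cc(Cl)cc(-c2nn(-c3cccc(NC(=O)Nc4ccc(Cl)c(Cl)c4)c3)cc2-c2ccncc2)c1` has not yet been measured. It differs from compound 2 in one place: chloro in place of trifluoromethyl on an aromatic carbon. The rest of the molecule, including the methoxy group and the shared core, is unchanged.

Among the compounds with values here, no pair of measured compounds isolates this exact change, so there is no measured step to lean on. Given that compound 1, which carries the same 3,4-dichlorophenyl group, gives 88%, and compound 2 gives 103%, the step is expected to be small, at most a modest move downward, and likely within the scatter: a number 7 percentage points lower from compound 2 to compound 3 (within the scatter). In this assay compound 3 is therefore estimated at 96%, within a range from 82% to 108%.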

Compound 3, a percentage reported as activity, at one concentration (the size of the read-out at that concentration, not a potency): 94%
Beside the measured number, compound 3's estimate is 2 percentage points above it, and the stated range covers the measured number.
By their numbers in this assay, from the lowest: compounds 1, 3 and 2 (each within the scatter of the next, the first and the last beyond it).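

In this assay, the change from 4-chloro-3-(trifluoromethyl)phenyl to 3,4-dichlorophenyl gives a number 9 percentage points lower from compound 2 to compound 3 (within the scatter), so at this position a trifluoromethyl group of 4 heavy atoms can give way to a single chlorine without a shift that stands clear of the usual variation. Compound 3 also connects to compound 1 through one other change, methyl in place of hydrogen on an oxygen on an aromatic ring, which gives a number 6 percentage points higher from compound 1 to compound 3 (within the scatter), so each of the two single changes, read alone, stays within the scatter, even though compounds 1 and 2, which differ in both places, lie further apart. No measurement at hand accounts for either step.

Going by these compounds, whether a different kind of group at this position, such as an amine or a carboxylic acid, would move the number beyond the scatter remains open. Also open, on these data alone, is how the same swap would read with hydrogen rather than methyl on that oxygen, and whether these small steps would hold at concentrations other than the single one tested here.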